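Swapping the fluorophenyl for a furan: compound 3 foreseen

The source may hold more compounds than are shown below. What is called first, only, known or untested is meant among the compounds shown, and "the series" means these compounds.

Compound 1 `COc1ccc(C(=O)/C=C/c2cccc(F)c2)c2c1C=CC(C)(C)O2` gives > 10000 nM in a functional assay on K562 cells (Homo sapiens) for antiproliferative activity, read by MTT assay, with a stated time of 24 h (on this read-out lower numbers stand for stronger inhibition and higher numbers for weaker inhibition), a limit of that assay.
Compound 2 `COc1ccc(C(=O)/C=C/c2cccc(C(F)(F)F)c2)c2c1C=CC(C)(C)O2` gives 7850 nM in this assay.

Compound 1 stands only at the limit of > 10000 nM in this assay, at which 1 of the 2 values shown sits, so no number is known for it. Among the compounds with values here, the one measured step, an at least 1.2-fold lower number from compound 1 to compound 2 (0.10 log units; that floor lies within the scatter), lies within the scatter. Compound 3 `COc1ccc(C(=O)/C=C/c2ccco2)c2c1C=CC(C)(C)O2` differs from compound 1 by furan-2-yl in place of 3-fluorophenyl on a double-bonded chain carbon bound to a double-bonded chain carbon. Within the data shown here, that step alters a substituent on the very ring compound 3 loses, so it does not bear on the change, and no measured step involves a furan. For compound 3 the expected step is a step that the limit leaves unreadable from compound 1 to compound 3. Compound 3 is estimated at 15000 nM, between 5000 nM and 40000 nM, with a fair chance that only a limit is reported.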

Compound 3, half-maximal inhibitory concentration: > 10000 nM
Compound 3 was reported as a limit; the forecaster's own chance of this, stated with the estimate: 60%; the middle value does not contradict the limit.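

No step can be read from compound 1 to compound 3, since both stand only at a limit: the limit of > 10000 nM in this assay, at which 2 of the 3 values shown sit. The compounds shown leave open whether furan-2-yl in place of 3-fluorophenyl changes the number in this assay at all.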